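This account rests on a few compounds, and the source may have more. Where it says the series, first, only, none or still open, it means among the compounds named here.

Measured so far:
Compound 1 `COc1ccc(-n2c(SCC(=O)c3ccc(OC)c(O)c3)nnc2-c2cc(OC)c(OC)c(OC)c2)cc1`: > 60000 nM, a limit
Compound 2 `COc1ccc(-n2c(SCC(=O)c3ccc4ccccc4c3)nnc2-c2cc(OC)c(OC)c(OC)c2)cc1`: > 60000 nM, a limit

In a functional assay on PC-3 cells (Homo sapiens) for inhibition, read by MTT assay, with a stated time of 48 h (on this read-out higher numbers stand for weaker inhibition and lower numbers for stronger inhibition), compound 2 gives > 60000 nM, which is a limit and not a number. Among the compounds with values here, the only measured step is a step that the two limits leave unreadable from compound 1 to compound 2, so it offers no size to carry forward. The evidence is simply (the limit of > 60000 nM in this assay, at which 2 of the 2 values shown sit). Compound 3 `COc1ccc(-n2c(SCC(=O)Nc3ccc(Cl)cc3)nnc2-c2cc(OC)c(OC)c(OC)c2)cc1` differs from compound 2 by (4-chlorophenyl)amino in place of naphthalen-2-yl on a carbonyl carbon. With no readable step, no clear direction can be expected in this assay, and weak inhibition remains the likely outcome. The expected change is an at least 1.5-fold lower number from compound 2 to compound 3 (0.17 log units; that floor lies within the scatter). For compound 3 the estimated value is 40000 nM, with an expected range of 10000 nM to 80000 nM.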

Compound 3, half-maximal inhibitory concentration: 6290 nM
Estimate against measurement, compound 3: 6.4-fold (0.80 log units) above, and the stated range ends above it.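

In this assay, the group on the carbonyl carbon proves able to move the read-out, which the two earlier compounds could not show: the change gives an at least 9.5-fold lower number from compound 2 to compound 3 (0.97 log units; beyond the scatter) and also an at least 9.5-fold lower number from compound 1 to compound 3 (0.97 log units; beyond the scatter) at the same place. Both steps are floors, and compound 3 is the only one of the three whose value is a number and not a limit: (the limit of > 60000 nM in this assay, at which 2 of the 3 values shown sit).

On these data alone, it remains open whether the step follows the amide hydrogen or the chlorine of the (4-chlorophenyl)amino group. An unsubstituted phenylamino group or a cyclohexylamino group at this carbonyl carbon would bear on that.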